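This account rests on a few compounds, and the source may have more. Where it says the series, first, only, none or still open, it means among the compounds named here.

Compound 3 `Cc1nc2c(OCc3ccccc3)cccn2c1C[S+](C)[O-]` is the starting point of the step described here. In a functional assay on the whole organism (stomach) for inhibition, with Canis familiaris (Canis lupus familiaris) as the target, at a dose of 5 mg/kg by the intravenous route (on this read-out lower numbers stand for a weaker effect and higher numbers for a stronger effect at the one dose given), compound 3 gives 18%, the highest of the three numbers recorded so far. Its nearest neighbour is compound 1 `CSCc1c(C)nc2c(OCc3ccccc3)cccn12`, which in this assay gives 8%; the step of a number 10 percentage points higher from compound 1 to compound 3 (within the scatter) lies within the scatter. Further off is compound 2 `CCSCc1c(C)nc2c(OCc3ccccc3)cccn12`, which in this assay gives 0%; the step of a number 18 percentage points higher from compound 2 to compound 3 (beyond the scatter) is beyond the scatter, while the step of a number 8 percentage points lower from compound 1 to compound 2 (within the scatter) stays within it.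

Compound 4 `Cc1nc2c(OCc3ccccc3)cccn2c1COC(=O)N(C)C` has not yet been measured. It differs from compound 3 in one place: a group of 6 heavy atoms (3 carbon, 1 nitrogen, 2 oxygen; no ring) in place of a group of 3 heavy atoms (1 carbon, 1 oxygen, 1 sulfur; no ring), on a saturated chain carbon bound to an aromatic carbon. The measured steps that bear on this change are the two that also exchange the group on the saturated chain carbon bound to an aromatic carbon, namely a number 10 percentage points higher from compound 1 to compound 3 (within the scatter) and a number 18 percentage points higher from compound 2 to compound 3 (beyond the scatter), the first within the scatter and the second modest but beyond it. Going by the values given here, neither of them brings in a (dimethylcarbamoyl)oxy group, and nothing among the measured compounds shows how such a group behaves at this place. The step expected from this change is therefore small and without a clear direction: the estimated step is a number 4 percentage points lower from compound 3 to compound 4 (within the scatter), expected to remain within the scatter. For compound 4 the value expected in this assay is 14%, estimated to fall between 0% and 40%.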

Compound 4, a percentage reported as inhibition, in the whole organism at one dose (the size of the read-out at that dose, not a potency): 23%
Estimate against measurement, compound 4: 9 percentage points below; the measured number falls inside the stated range.
By their numbers in this assay, from the lowest: compounds 2, 1, 3 and 4 (each within the scatter of the next, the first and the last beyond it).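

In this assay, (dimethylcarbamoyl)oxy on a saturated chain carbon bound to an aromatic carbon does not separate from the sulfur-bearing group of compound 3: the exchange gives a number 5 percentage points higher from compound 3 to compound 4 (within the scatter), so these two compounds cannot be put in order. Against the simple sulfanyl groups the same place does show a difference, with a number 23 percentage points higher from compound 2 to compound 4 (beyond the scatter) on replacing ethylsulfanyl and a number 15 percentage points higher from compound 1 to compound 4 (beyond the scatter) on replacing methylsulfanyl, both modest; compound 1, which no earlier step set clearly apart from compound 3, now stands clearly apart from compound 4, and the place is thus shown to accept a group without sulfur and with a carbonyl while the read-out stays as high as any seen so far. Nothing shown here explains why these steps take the size they do.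

Going by these compounds, it remains open whether the carbonyl, the nitrogen or its two methyl groups carry the difference from the sulfanyl compounds, and how a longer chain on that nitrogen, an amine or a carboxylic acid would read at this place. With a single dose shown, the compounds also leave open how these steps would look at any other dose.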